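The compounds below may be only part of what the source reports. "The series", "measured", "known", "first", "only" and "open" are said of these compounds alone.

The study gathers three measured compounds on a shared core and one that awaits measurement. Compound 1, `CC1CCCc2c1[nH]c(=O)c(C#N)c2-c1cccn1C`, sits with its nitrile and carbonyl on a saturated-fused core. In a functional assay on HCT-116 cells (Homo sapiens) for inhibition, read by sulforhodamine B assay, with a stated time of 48 h (a higher number here means a weaker inhibitor of growth, a lower number a stronger inhibitor of growth), compound 1 gives only a limit, > 100000 nM. Compound 2, `Cn1cccc1-c1cc(-c2cccs2)nc(N)c1C#N`, carries a thiophen-2-yl group. In this assay compound 2 likewise gives only a limit, > 100000 nM. For the measured compounds named here, compound 3, `COc1ccc(-c2cc(-c3cccn3C)c(C#N)c(N)n2)cc1OC`, carries a dimethoxyphenyl group in the same place, and in this assay compound 3 gives 89100 nM, the one numeric reading of the set.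

Going by the values given here, compound 2 therefore stands at the ceiling of the data, since the limit of > 100000 nM in this assay, at which 2 of the 3 values shown sit, marks where its reading rests, and no step between measured compounds can be drawn from it. Compound 4, `Cn1cccc1-c1cc(-c2ccccc2)nc(N)c1C#N`, is the compound still to be measured. It differs from compound 2 by phenyl in place of thiophen-2-yl on an aromatic carbon.

With compound 2 at the limit and compound 3 only a little beneath it, there is no measured change to lean on. The step expected a number no higher from compound 2 to compound 4 (the limit leaves the size open) is none beyond the scatter. Compound 4 is thus expected to give about 100000 nM in this assay, within a range from 40000 nM to 300000 nM, with a fair chance that only a limit is returned.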

Compound 4, concentration for 50% growth inhibition: > 100000 nM
Compound 4 ended at the assay's limit; the forecaster's own chance of this, stated with the estimate: 60%; the middle value lies on the limit itself.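

Compound 2 and compound 4 both rest at a limit in this assay, so the change to phenyl in place of thiophen-2-yl gives no step that can be read: the limit of > 100000 nM in this assay, at which 3 of the 4 values shown sit.

The compounds shown leave open whether phenyl and thiophen-2-yl differ at all in their effect on growth inhibition.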